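A few compounds are considered here, and "the series" means these few. Any claim that something is new, unique, unknown or untested is made for them only; others in the source may bear on it.

Measured so far:
compound 1, `O=C(CN1CN(c2ccccc2)C2(CCN(C(=O)c3ccc(C4CCCCC4)cc3)CC2)C1=O)N1CCC(CO)CC1`, in an assay on HEK293 cells for displacement of a labelled ligand from NPC1-like intracellular cholesterol transporter 1 (Homo sapiens) (a higher number here means a weaker inhibitor, a lower number a stronger inhibitor), gives 1100 nM
compound 2, `CC(C)(C)OC(=O)NCCCCNC(=O)CN1CN(c2ccccc2)C2(CCN(C(=O)c3ccc(C4CCCCC4)cc3)CC2)C1=O`, in this assay gives 4600 nM

Of these two numbers, compound 2 holds the higher one; compound 1 sits lower, and that gap lies beyond the usual scatter of repeated measurements, so compound 2 counts as the weaker of the pair in this assay. Compound 3, `CS(=O)(=O)NCCCNC(=O)CN1CN(c2ccccc2)C2(CCN(C(=O)c3ccc(C4CCCCC4)cc3)CC2)C1=O`, keeps the shared core and alters only the tail: methanesulfonamido in place of ((tert-butoxycarbonyl)amino)methyl on a saturated chain carbon, three bonds along the chain from an amide-type nitrogen. Among the compounds with values here, no step between two measured compounds isolates this kind of exchange, so there is no measured precedent to lean on. The expectation rests on compound 2 alone, with a modest move downward: compound 3 is estimated at 3000 nM, with a range from 1000 nM to 9000 nM, which amounts to an expected step of a 1.5-fold lower number from compound 2 to compound 3 (0.19 log units; within the scatter) that may well fall inside the scatter.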

Compound 3, half-maximal inhibitory concentration: 3800 nM
The estimate for compound 3 lay 1.3-fold (0.10 log units) below the measured number; the measured number falls inside the stated range.
By their numbers in this assay, from the lowest: compound 1; then compounds 3 and 2 (each within the scatter of the next).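

In this assay, exchanging ((tert-butoxycarbonyl)amino)methyl for methanesulfonamido gives a 1.2-fold lower number from compound 2 to compound 3 (0.08 log units; within the scatter), so this position accepts a group of 5 heavy atoms in place of one of 9 with no readable shift in the number. The exchange of 4-(hydroxymethyl)piperidin-1-yl on a carbonyl carbon for (3-(methanesulfonamido)propyl)amino gives a 3.5-fold higher number from compound 1 to compound 3 (0.54 log units; beyond the scatter), a modest step beyond the scatter, so the change at this carbonyl carbon can be read where the exchange further along the chain cannot. Nothing at hand accounts for either result.

The first exchange also reads as 4-((tert-butoxycarbonyl)amino)butyl to 3-(methanesulfonamido)propyl, so chain length and end group change together and their contributions cannot be separated. On these data alone, how a primary amine or a carboxylic acid at the end of the chain would behave remains open, as does the effect of a longer chain carrying methanesulfonamido.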